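The source may hold more compounds than are shown below. What is called first, only, known or untested is meant among the compounds shown, and "the series" means these compounds.

- compound 1 `Cc1ccc(S(=O)(=O)NC(=O)c2cccnc2)cc1`: 12000 nM
- compound 2 `O=C(NS(=O)(=O)c1ccccc1)c1ccc(Cl)nc1`: 14100 nM
- compound 3 `Cc1ccc(S(=O)(=O)NC(=O)c2ccc(Cl)nc2)cc1`: 17200 nM

In a functional assay on MCF7 cells (Homo sapiens) for antiproliferative activity, read by MTT assay, with a stated time of 48 h (a lower number here means a stronger inhibitor, a higher number a weaker inhibitor), compound 3 gives 17200 nM, within the scatter of both compound 1 and compound 2. Compound 4 `O=C(NS(=O)(=O)c1ccc(F)cc1)c1ccc(Cl)nc1` has fluoro in place of methyl on an aromatic carbon, para to a large group (fluoro in place of methyl on an aromatic carbon). The closest measured evidence is the methyl step at this place, a 1.2-fold higher number from compound 2 to compound 3 (0.09 log units; within the scatter). The chloro step elsewhere, a 1.4-fold higher number from compound 1 to compound 3 (0.16 log units; within the scatter), is similarly small. Within the data shown here, no measured compound carries fluoro, so this rests on small steps alone, and no shift beyond the scatter is expected. The expected change is a 1.1-fold lower number from compound 3 to compound 4 (0.06 log units; within the scatter). For compound 4 the estimated value is 15000 nM, with an expected range of 8000 nM to 28000 nM.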

Compound 4, half-maximal inhibitory concentration: 16800 nM
Estimate against measurement, compound 4: 1.1-fold (0.05 log units) below; measured number inside the range.
By their numbers in this assay, from the lowest: compounds 1, 2, 4 and 3 (each within the scatter of the next).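

In this assay fluoro in place of methyl gives a 1.0-fold lower number from compound 3 to compound 4 (0.01 log units; within the scatter) and fluoro in place of hydrogen gives a 1.2-fold higher number from compound 2 to compound 4 (0.08 log units; within the scatter) at this place on the aromatic carbon. Hydrogen, methyl and fluoro therefore read alike here, which the methyl step alone could not show. No evidence is at hand that would explain this.

From the compounds shown here alone, whether an amine or a carboxylic acid at this place would move the number beyond the scatter stays open. So does whether fluoro reads the same on the core of compound 1, which lacks the chloro.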